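This account rests on a few compounds, and the source may have more. Where it says the series, first, only, none or still open, it means among the compounds named here.

Working notes on the series. Of the compounds shown here, three built on the shared core have been measured in a functional assay on thoracic aorta for antagonist activity at Alpha-1D adrenergic receptor (Rattus norvegicus); on this read-out higher numbers stand for higher potency (the scale is a negative logarithm) and lower numbers for lower potency. Compound 1 `COc1cccc(OC)c1OCCNCCOc1ccccc1OCc1ccccc1` gives 9.37. Compound 2 `COc1cccc(OC)c1OCCNCCOc1ccccc1OCc1cccc(Cl)c1` gives 8.72. Compound 3 `COc1cccc(OC)c1OCCNCCOc1ccccc1OCc1cccc([N+](=O)[O-])c1` gives 9.28. Of the three numbers compound 3 stands second highest; the nearest number lies within the scatter, as the step of a number 0.09 log units lower from compound 1 to compound 3 (within the scatter) shows, and the furthest lies beyond it, as a number 0.56 log units higher from compound 2 to compound 3 (beyond the scatter) shows.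

Compound 4 `COc1cccc(OC)c1OCCNCCOc1ccccc1OCc1ccc(OC(C)C)cc1` is not yet measured. It differs from compound 3 by 4-isopropoxyphenyl in place of 3-nitrophenyl on a saturated chain carbon bound to an oxygen on an aromatic ring. All three measured steps exchange one group for another at that same place: a number 0.65 log units lower from compound 1 to compound 2 (beyond the scatter), the within-scatter step a number 0.09 log units lower from compound 1 to compound 3 (within the scatter), and a number 0.56 log units higher from compound 2 to compound 3 (beyond the scatter). For the measured compounds named here, none of them puts an isopropoxy group on that ring, so the entering group has no precedent here; what the data show is that removing the nitro group costs little, while a chloro in place of hydrogen gave a modest loss. A step of at most modest size is therefore expected in this assay, more likely downward than upward, with a wide range reflecting the missing precedent. The step of a number 0.38 log units lower from compound 3 to compound 4 (beyond the scatter) is the expected change. Compound 4 is estimated at 8.9, within a range from 8.2 to 9.5.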

Compound 4, negative logarithm of the antagonist equilibrium constant: 9.14
The estimate for compound 4 lay 0.24 log units below the measured number; low and high end bracket the measured number.
By their numbers in this assay, from the lowest: compound 2; then compounds 4, 3 and 1 (each within the scatter of the next).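

In this assay the 4-isopropoxyphenyl group is accepted on a saturated chain carbon bound to an oxygen on an aromatic ring: the steps read a number 0.23 log units lower from compound 1 to compound 4 (within the scatter) and a number 0.14 log units lower from compound 3 to compound 4 (within the scatter), so this group joins hydrogen and the 3-nitro group as a ring pattern that holds the number. Compound 2 now stands alone among the four compounds, with a number 0.42 log units higher from compound 2 to compound 4 (beyond the scatter), which means that the modest loss seen with chloro is not shared by every substituted benzyl group shown. Nothing available explains why the 3-chlorophenyl compound departs from the other three.

The steps from compound 2 and compound 3 to compound 4 change both the group and its place on the ring at once, so the compounds shown cannot separate the two contributions. On these data alone, whether a 4-chlorophenyl group, or a ring carrying an amine or a carboxylic acid, would follow compound 2 or stay with compounds 1, 3 and 4 remains open.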